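One More Methoxy on Compound 2

The compounds below may be only part of what the source reports. "The series", "measured", "known", "first", "only" and "open" are said of these compounds alone.

In a functional assay on MCF7 cells (Homo sapiens) for antiproliferative activity, read by MTT assay, with a stated time of 48 h (on this read-out lower numbers stand for stronger inhibition and higher numbers for weaker inhibition), compound 1 (`COc1cc(C2=N/C(=C\c3cc(Br)cc(Br)c3OC(C)=O)C(=O)NN2C(N)=S)cc(OC)c1OC`) gives 360 nM and compound 2 (`COc1ccc(C2=N/C(=C\c3cc(Br)cc(Br)c3OC(C)=O)C(=O)NN2c2ncc(-c3ccc(Br)cc3)s2)cc1OC`) gives 3280 nM as the higher of the two numbers, a gap beyond the scatter. Compound 2 is therefore the weaker inhibitor of this pair. Compound 3 (`COc1cc(C2=N/C(=C\c3cc(Br)cc(Br)c3OC(C)=O)C(=O)NN2c2ncc(-c3ccc(Br)cc3)s2)cc(OC)c1OC`) differs from compound 2 by a single change, methoxy in place of hydrogen on an aromatic carbon in which methoxy takes the place of hydrogen on an aromatic carbon, so that 3,4-dimethoxyphenyl becomes 3,4,5-trimethoxyphenyl. Within the data shown here, no measured step between these compounds shows the effect of such a change. Only a modest shift toward a lower number is therefore expected in this assay and it may not go beyond the scatter. The expected step is a 1.6-fold lower number from compound 2 to compound 3 (0.21 log units; within the scatter) and it is small. Compound 3 is estimated at 2000 nM with an expected range of 700 nM to 5500 nM in this measurement.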

Compound 3, half-maximal inhibitory concentration: 3160 nM
Estimate against measurement, compound 3: 1.6-fold (0.20 log units) below; low and high end bracket the measured number.
By their numbers in this assay, from the lowest: compound 1; then compounds 3 and 2 (each within the scatter of the next).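

In this assay, methoxy in place of hydrogen on an aromatic carbon, which turns 3,4-dimethoxyphenyl into 3,4,5-trimethoxyphenyl, gives a 1.0-fold lower number from compound 2 to compound 3 (0.02 log units; within the scatter), so at this position the added methoxy leaves the read-out within the scatter. Compound 3 also isolates the group on the amine nitrogen in a ring, which compounds 1 and 2 could not do because they differ in two places: a group of 12 heavy atoms in place of a group of 3 heavy atoms gives an 8.8-fold higher number from compound 1 to compound 3 (0.94 log units; beyond the scatter). No evidence at hand bears on either result.

On these data alone, whether an amine, a hydroxyl group or a longer alkoxy chain at this position would read like methoxy remains open. So does whether the methoxy step would read the same with the group of 3 heavy atoms on that nitrogen.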